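From propylamino to allylamino in a cell assay

The source may hold more compounds than are shown below. What is called first, only, known or untested is meant among the compounds shown, and "the series" means these compounds.

Compound 1 `COc1cc(/C=C/C(=O)/C=C(/C=C/c2ccc(OC(C)=O)c(OC)c2)NC2CCCCC2)ccc1OC(C)=O`: > 25000 nM
Compound 2 `CCCNC(=C\C(=O)/C=C/c1ccc(O)c(OC)c1)/C=C/c1ccc(O)c(OC)c1`: > 25000 nM

In a functional assay on HT-29 cells (Homo sapiens) for inhibition, read by sulforhodamine B assay, with a stated time of 72 h (on this read-out lower numbers stand for stronger inhibition and higher numbers for weaker inhibition), compound 2 gives > 25000 nM, which is a limit of the assay and not a number. Compound 1 gives > 25000 nM, likewise a limit. Compound 2 thus stands at the limit of > 25000 nM in this assay, at which 2 of the 2 values shown sit, without a measured number. Compound 3 `C=CCNC(=C\C(=O)/C=C/c1ccc(O)c(OC)c1)/C=C/c1ccc(O)c(OC)c1` differs from it in one place: vinyl in place of ethyl on a saturated chain carbon bound to an amine nitrogen, which reads propyl to allyl. Within the data shown here, no measured step covers this change. In this assay no step in either direction beyond the scatter is expected, the estimated step being a step that the limit leaves unreadable from compound 2 to compound 3. For compound 3 the estimate is 28000 nM, expected within 12000 nM to 60000 nM.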

Compound 3, half-maximal inhibitory concentration: 24600 nM
Compound 3: middle estimate off by 1.1-fold (0.06 log units), on the high side, within the range that was stated.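

In this assay, compound 3 gives 24600 nM, the only measured number among the compounds shown, so an allylamino group at this position gives a readable value. Read from the propylamino compound, the change gives an at least 1.0-fold lower number from compound 2 to compound 3 (0.00 log units; that floor lies within the scatter). Compound 2 stands at a limit of the assay and not at a number, so the true size of the step stays unread: the limit of > 25000 nM in this assay, at which 2 of the 3 values shown sit.

Going by these compounds, it remains open whether a longer chain or a benzyl group in place of allyl would give a clearly lower number than compound 3. On these data alone, whether a free amine there would do so is equally open.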